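Sulfonyl aryl swaps on a shared quinazoline-free core series

The compounds below may be only part of what the source reports. "The series", "measured", "known", "first", "only" and "open" are said of these compounds alone.

Compound 2 `COc1cc2nc(N3CCN(S(=O)(=O)c4ccc(C(=O)O)cc4)CC3)nc(N)c2cc1OC` gives 53000 nM in a functional assay on PC-3 cells (Homo sapiens) for inhibition; a higher number here means a weaker inhibitor, a lower number a stronger inhibitor; compound 1 `COc1cc2nc(N3CCN(S(=O)(=O)c4cccc([N+](=O)[O-])c4)CC3)nc(N)c2cc1OC` gives 32000 nM in this assay , and the two values lie within the scatter of each other, the step being a 1.7-fold higher number from compound 1 to compound 2 (0.22 log units; within the scatter). Compound 3 `COc1cc2nc(N3CCN(S(=O)(=O)c4ccc(N)cc4N)CC3)nc(N)c2cc1OC` carries the change (2,4-diaminophenyl in place of 4-carboxyphenyl on a sulfonyl sulfur). Among the measured compounds shown here, the only measured step that bears on it is the exchange of the aryl group on the same sulfonyl sulfur, from compound 1 to compound 2, which came out as a 1.7-fold higher number from compound 1 to compound 2 (0.22 log units; within the scatter). With one aryl swap at this position showing no effect beyond the scatter, no step beyond the scatter is expected for the next swap either, in either direction, though a single precedent is thin ground. Compound 3 is therefore expected at 42000 nM in this assay , with a range from 15000 nM to 120000 nM, meaning an estimated step of a 1.3-fold lower number from compound 2 to compound 3 (0.10 log units; within the scatter).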

Compound 3, half-maximal inhibitory concentration: 67000 nM
Estimate against measurement, compound 3: 1.6-fold (0.20 log units) below; measured number inside the range.
By their numbers in this assay, from the lowest: compounds 1, 2 and 3 (each within the scatter of the next, the first and the last beyond it).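

In this assay, the exchange of 4-carboxyphenyl for 2,4-diaminophenyl on the sulfonyl sulfur gives a 1.3-fold higher number from compound 2 to compound 3 (0.10 log units; within the scatter), so these two aryl groups cannot be told apart here. Among the compounds shown here, the comparison with the 3-nitrophenyl of compound 1 gives a 2.1-fold higher number from compound 1 to compound 3 (0.32 log units; beyond the scatter), the first step at this position to pass the scatter, though only modestly, while compound 2 stays within the scatter of both neighbours. Nothing available accounts for this small separation.

Going by these compounds, it remains open whether an aryl group carrying a single amine would behave like the 2,4-diaminophenyl of compound 3, and so whether either amine matters on its own. Also open, on these data alone, is whether an unsubstituted phenyl or an alkyl chain on the sulfonyl sulfur would move the number beyond the scatter in either direction.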